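The compounds below may be only part of what the source reports. "The series", "measured", "known", "first", "only" and "open" are said of these compounds alone.

Compound 1 `Nc1ncnn2c([C@@H]3O[C@H](CO)[C@@H](O)[C@H]3O)cc(C#Cc3ccc(F)cc3)c12` was tested in a functional assay on LN-229 cells (Homo sapiens) for antiproliferative activity, with a stated time of 72 h; on this read-out lower numbers stand for stronger inhibition and higher numbers for weaker inhibition. In this assay compound 1 gives > 100000 nM, which is a limit of the assay rather than a number. Compound 2 `Nc1ncnn2c([C@@H]3O[C@H](CO)[C@@H](O)[C@H]3O)cc(-c3ccccc3F)c12` gives > 100000 nM, again a limit. Compound 3 `Nc1ncnn2c([C@@H]3O[C@H](CO)[C@@H](O)[C@H]3O)cc(-c3ccc(F)cc3F)c12` gives 43500 nM. Compound 1 therefore stands at the edge of what can be read, at the limit of > 100000 nM in this assay, at which 2 of the 3 values shown sit. The step that the two limits leave unreadable from compound 1 to compound 2 cannot be sized, while an at least 2.2-fold lower number from compound 1 to compound 3 (0.36 log units; beyond the scatter) and an at least 2.2-fold lower number from compound 2 to compound 3 (0.36 log units; beyond the scatter) are readable. Compound 4 `Nc1ncnn2c([C@@H]3O[C@H](CO)[C@@H](O)[C@H]3O)cc(-c3ccoc3)c12` differs from compound 1 by furan-3-yl in place of 2-(4-fluorophenyl)ethynyl on an aromatic carbon. With the steps from compound 1 largely unreadable, the expected step of an at least 1.2-fold lower number from compound 1 to compound 4 (0.09 log units; that floor lies within the scatter) is small or none beyond the scatter. Compound 4 is thus estimated at 80000 nM, between 25000 nM and 200000 nM.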

Compound 4, half-maximal inhibitory concentration: 1000 nM
The estimate for compound 4 lay 80-fold (1.90 log units) above the measured number; the measured number lies below the stated range.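

Changing the group on this aromatic carbon can move activity strongly in this assay: furan-3-yl gives an at least 100-fold lower number from compound 1 to compound 4 (2.00 log units; beyond the scatter), an at least 100-fold lower number from compound 2 to compound 4 (2.00 log units; beyond the scatter) and a 44-fold lower number from compound 3 to compound 4 (1.64 log units; beyond the scatter). Within the data shown here, the earlier compounds, which carry larger groups, showed only a shift at the edge of the readable range, whereas compound 4 is the first to show that this place can bring activity well inside it. The first and second of these steps are minimum sizes, as they start from a limit of the assay: the limit of > 100000 nM in this assay, at which 2 of the 4 values shown sit.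

With one five-membered ring shown, it remains open whether the ring oxygen, the ring size or the smaller group matters. On these data alone, how a thiophene ring or an amine would read at this place also stays open.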